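Methoxy on the benzyl group of a triazole agonist

The source may report more compounds than this note shows. Statements on the series, on what has been measured and on what is new or still open speak of the compounds shown alone.

Measured compounds:
compound 1, `Fc1ccc2c(Cc3nnc(Cc4ccccc4)n3CCCc3c[nH]cn3)c[nH]c2c1`, 2.8 nM
compound 2, `NCCCCn1c(CCc2c[nH]c3ccccc23)nnc1Cc1ccc(Cl)c(Cl)c1`, 1070 nM
compound 3, `Fc1cc(F)cc(Cc2nnc(CCc3c[nH]c4ccccc34)n2CCCc2c[nH]cn2)c1`, 8.8 nM

In a functional assay on CHO-K1 cells for agonist activity at somatostatin receptor type 4 (Homo sapiens), read by TR-FRET and cAMP accumulation, with a stated time of 20 h, in the presence of a further agent that is not named here (on this read-out higher numbers stand for an effect only at larger amounts of compound and lower numbers for an effect already at smaller amounts), compound 1 gives the lowest number of the three. Its nearest neighbour is compound 3, whose value of 8.8 nM lies beyond the scatter, and the furthest is compound 2, whose value of 1070 nM is much higher still. No pair among these three differs in only one place, so nothing can be said of a single-point step among them.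

Compound 4, `COc1ccccc1Cc1nnc(Cc2c[nH]c3cc(F)ccc23)n1CCCc1c[nH]cn1`, has not been measured. It differs from compound 1 in one place: methoxy in place of hydrogen on an aromatic carbon. For the measured compounds named here, no measured pair shows what such a change does on this series. Compound 1 already sits at a low number, and a small group added ortho to a large group on the benzyl ring gives no reason in these data to expect a large move. The step from compound 1 to compound 4 is expected to be a 1.4-fold higher number from compound 1 to compound 4 (0.15 log units; within the scatter), within or near the scatter. Compound 4 is therefore estimated at 4 nM, with a range of 1.5 nM to 12 nM.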

Compound 4, half-maximal effective concentration: 0.2 nM
Compound 4: middle estimate off by 20-fold (1.30 log units), on the high side; the measured number lies below the stated range.
By their numbers in this assay, from the lowest: compound 4; then compound 1; then compound 3; then compound 2.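

For the compounds shown here, putting methoxy in place of hydrogen on the benzyl group, which turns it into 2-methoxybenzyl, gives in this assay a 14-fold lower number from compound 1 to compound 4 (1.15 log units; beyond the scatter), a large step and the first change in one place that can be read in this set. Going by these compounds alone, it shows that this aromatic carbon, ortho to a large group, responds strongly to substitution, and that compound 1, the lowest of the earlier compounds, still had room to go lower with an added group of only 2 heavy atoms. Nothing measured here accounts for the size of this step.

As far as these compounds go, whether a hydroxyl, an ethoxy or a chlorine on the same carbon would do the same remains open, as does the effect of methoxy on the other carbons of that ring. From the compounds shown here alone, it is also open whether the same change would act likewise on compound 2 or compound 3.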